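The compounds below may be only part of what the source reports. "The series", "measured", "known", "first", "only" and "open" are said of these compounds alone.

Compound 1 `CS(=O)(=O)c1ccc(C(=O)NCCC(=O)N2CCCCC2)cc1[N+](=O)[O-]` and compound 2 `CC1CCN(C(=O)CCNC(=O)c2ccc(S(C)(=O)=O)c([N+](=O)[O-])c2)CC1` share one core and differ only in a methyl on a saturated ring carbon. In an assay on isolated protein for inhibition of thyroid hormone receptor alpha (Homo sapiens), read by fluorescence polarization (a higher number here means a weaker inhibitor, a lower number a stronger inhibitor), compound 1 reaches only a limit, > 60000 nM. Compound 2 likewise reaches only a limit in this assay, > 60000 nM. The step that the two limits leave unreadable from compound 1 to compound 2 is therefore unreadable, since both values sit at the limit of > 60000 nM in this assay, at which 2 of the 2 values shown sit. Compound 3 `CC(C)N(C(=O)CCNC(=O)c1ccc(S(C)(=O)=O)c([N+](=O)[O-])c1)C(C)C` differs from compound 2 by diisopropylamino in place of 4-methylpiperidin-1-yl on a carbonyl carbon. Going by the values given here, no measured step gives a number, so the step expected for a step that the limit leaves unreadable from compound 2 to compound 3 is none beyond the scatter. Compound 3 is thus expected at the same limit, with an estimate of 100000 nM and a range from 60000 nM to 300000 nM.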

Compound 3, half-maximal inhibitory concentration: > 60000 nM
Compound 3 gave a limit, no number; the forecaster's own chance of this, stated with the estimate: 90%; the middle value is on the limit's open side.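

Going by these compounds alone, compound 1, compound 2 and compound 3 all stop at a limit in this assay and so no step between them can be read: the limit of > 60000 nM in this assay, at which 3 of the 3 values shown sit.

Which change to the shared core, if any, would give a readable number remains open.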